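The source may hold more compounds than are shown below. What is called first, only, known or untested is meant among the compounds shown, and "the series" means these compounds.

Compound 1 `ClCc1ccccc1Cn1cnc2ncnc(Cl)c21` gives 24500 nM in a functional assay on SF-268 cells (Homo sapiens) for cytotoxicity, read by sulforhodamine B assay, with a stated time of 48 h; on this read-out lower numbers stand for stronger inhibition of growth and higher numbers for weaker inhibition of growth.
Compound 2 `ClCc1ccc(Cn2cnc3c(Cl)nc(Cl)nc32)cc1` gives 5370 nM in this assay.
Compound 3 `Nc1nc(Cl)c2ncn(Cc3cccc(CCl)c3)c2n1` gives 10200 nM in this assay.

Among these three, compound 1 stands at the top of the numbers, which in this assay marks it as the weakest inhibitor of growth in the set; its gaps to compound 3 and to compound 2 both lie beyond the usual scatter of the measurement. The step under consideration leads from compound 1 to compound 4 `ClCc1ccccc1Cn1cnc2nc(Cl)nc(Cl)c21`, a compound not yet measured. The change is chloro in place of hydrogen on an aromatic carbon. Within the data shown here, no measured pair shows this exact change on the same core, so there is no recorded step to lean on. What the numbers do show is that compound 2, which carries two chloro groups on its core, gives 5370 nM, and compound 3, with an amino group on its core, gives 10200 nM, both lower than compound 1; yet both also differ from compound 1 in how the benzyl group is substituted, so the comparison is not clean. On this basis a modest move toward a lower number is expected for compound 4, with the step from compound 1 to compound 4 estimated as a 2.2-fold lower number from compound 1 to compound 4 (0.35 log units; beyond the scatter). Compound 4 is therefore expected to give about 11000 nM in this assay, within a range from 4500 nM to 27000 nM.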

Compound 4, concentration for total growth inhibition: 24500 nM
Beside the measured number, compound 4's estimate is 2.2-fold (0.35 log units) below it, within the range that was stated.
By their numbers in this assay, from the lowest: compounds 2 and 3 (each within the scatter of the next); then compounds 1 and 4 (each within the scatter of the next).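

In this assay, chloro in place of hydrogen on the aromatic carbon between two ring nitrogen atoms gives no change at the digits printed from compound 1 to compound 4 (within the scatter). Among these compounds, this is the first step in the set that isolates a single change on the shared core, something the earlier compounds, which differ in more than one place, could not provide, and it shows that adding this chloro group to compound 1 leaves the read-out within the scatter. No measurement at hand accounts for this outcome.

From the compounds shown here alone, the result concerns one substituent at one position on one scaffold, so it remains open whether a methoxy group or a carboxylic acid on this aromatic carbon would also leave the growth-inhibition read-out within the scatter. Going by these compounds, it is also open whether chloro in place of hydrogen at this position would give the same result with a different substitution on the benzyl group, and a single step in a single cell line cannot settle either question.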